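A few compounds are considered here, and "the series" means these few. Any claim that something is new, unique, unknown or untested is made for them only; others in the source may bear on it.

Compound 1 `N#Cc1ccc(-c2cn(CC(=O)Nc3nc4ccccc4s3)nn2)cc1` is one of three members of the series measured in a functional assay on BMDM cells (Mus musculus, strain C57BL/6) for inhibition, with a stated time of 2 days; on this read-out higher numbers stand for weaker inhibition and lower numbers for stronger inhibition. In this assay compound 1 gives only a limit, > 30000 nM. Compound 2 `Cc1cc(NC(=O)Cn2cc(-c3ccncc3)nn2)no1` gives 430 nM in this assay. Compound 3 `Cc1cc(NC(=O)Cn2cc(-c3cccs3)nn2)no1` likewise returns only a limit in this assay, > 30000 nM. Going by the values given here, the sole step between measured compounds that differ in one place is an at least 69-fold higher number from compound 2 to compound 3 (1.84 log units; beyond the scatter), showing that exchanging the aromatic group attached to the shared core can shift the read-out across the whole measurable window. On these data alone, compound 1 stands at the floor of the data: the limit of > 30000 nM in this assay, at which 2 of the 3 values shown sit, so its true value is unknown.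

Compound 4 `O=C(Cn1cc(-c2ccc(Cl)cc2)nn1)Nc1nc2ccccc2s1` differs from compound 1 by one change, (chloro in place of cyano on an aromatic carbon), on an aromatic carbon of a six-membered aromatic ring of carbon only. Among the compounds with values here, no measured step concerns this exchange; the step from compound 2 to compound 3 touches a different part of the aromatic group. With compound 1 anchored at a limit, direction cannot be read from the data. Compound 4 is expected near 20000 nM, between 3000 nM and 60000 nM, with a fair chance of another limit. The estimated step is an at least 1.5-fold lower number from compound 1 to compound 4 (0.17 log units; that floor lies within the scatter).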

Compound 4, half-maximal inhibitory concentration: 130 nM
Estimate against measurement, compound 4: 150-fold (2.19 log units) above; the whole stated range lies above it.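

Exchanging only cyano for chloro, on an aromatic carbon para to a large group, gives an at least 230-fold lower number from compound 1 to compound 4 (2.36 log units; beyond the scatter), so a single substituent at this place is enough to turn a compound with no measured potency into one with a measured value in this assay. The earlier step, an at least 69-fold higher number from compound 2 to compound 3 (1.84 log units; beyond the scatter), exchanged the whole aromatic group, whereas here the six-membered aromatic ring of carbon only stays and just its substituent changes. This step is a floor and not a measured gap, as the value of compound 1 is a limit: the limit of > 30000 nM in this assay, at which 2 of the 4 values shown sit.

Open, on these data alone, is how fluoro, methyl, methoxy or an amine at this place would read against chloro. Also open, as far as these compounds go, is whether 4-chlorophenyl would have the same effect on the core of compound 3.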